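The source may hold more compounds than are shown below. What is called first, only, known or untested is meant among the compounds shown, and "the series" means these compounds.

Measured compounds:
Compound 1 `COc1ccc(OC)c(/C=N/NC(=O)Nc2ccc(Oc3ccnc(-c4nncn4CCN(C)C)c3)c(F)c2)c1` — in a functional assay on NCI-H460 cells (Homo sapiens) for cytotoxicity, read by MTT assay, with a stated time of 72 h (on this read-out higher numbers stand for weaker inhibition and lower numbers for stronger inhibition), compound 1 gives 2930 nM.
Compound 2 `CN(C)CCn1cnnc1-c1cc(Oc2ccc(NC(=O)N/N=C/c3ccc(F)cc3)cc2F)ccn1` — in this assay compound 2 gives 1980 nM.
Compound 3 `CN(C)CCn1cnnc1-c1cc(Oc2ccc(NC(=O)N/N=C/c3ccc(O)c(O)c3)cc2F)ccn1` — in this assay compound 3 gives 1930 nM.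

Compound 3 holds the lowest of the three numbers, but its neighbours sit within the scatter of it, so no order among the three can be read. Compound 4 `CN(C)CCn1cnnc1-c1cc(Oc2ccc(NC(=O)N/N=C/c3ccc(Cl)cc3)cc2F)ccn1` differs from compound 3 in one place: 4-chlorophenyl in place of 3,4-dihydroxyphenyl on a carbon with a double bond to nitrogen. For the measured compounds named here, two measured steps bear on this change. The step of a 1.0-fold lower number from compound 2 to compound 3 (0.01 log units; within the scatter) swaps a halogen-bearing ring for the dihydroxyphenyl and is flat; the step of a 1.5-fold lower number from compound 1 to compound 3 (0.18 log units; within the scatter) is also within the scatter. Compound 2, carrying the 4-fluorophenyl, is the nearest analogue of compound 4, and its value lies close to that of compound 3. The step of a 1.0-fold higher number from compound 3 to compound 4 (0.02 log units; within the scatter) is therefore expected to stay within the scatter, with no clear direction. Compound 4 is estimated at 2000 nM, in the range 1000 nM to 4000 nM.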

Compound 4, half-maximal inhibitory concentration: 320 nM
Compound 4: middle estimate off by 6.3-fold (0.80 log units), on the high side; measured number outside the range, below it.
By their numbers in this assay, from the lowest: compound 4; then compounds 3, 2 and 1 (each within the scatter of the next).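

In this assay, the aryl group on the carbon with a double bond to nitrogen had seemed not to matter, but the position does respond: chloro in place of fluoro on an aromatic carbon alone gives a 6.2-fold lower number from compound 2 to compound 4 (0.79 log units; beyond the scatter). The 4-chlorophenyl also stands apart from the two oxygen-bearing rings, with a 6.0-fold lower number from compound 3 to compound 4 (0.78 log units; beyond the scatter) and a 9.2-fold lower number from compound 1 to compound 4 (0.96 log units; beyond the scatter). Nothing measured here accounts for this difference.

On these data alone, whether a bromo, methyl or trifluoromethyl group in place of the chloro would keep the lower number remains open.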